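A few compounds are considered here, and "the series" means these few. Any claim that something is new, unique, unknown or untested is made for them only; others in the source may bear on it.

Measured in an ADME assay on Vero cells (Chlorocebus sabaeus) for cytotoxicity, read by CellTiter-Glo, with a stated time of 72 h; on this read-out lower numbers stand for higher toxicity in this test and higher numbers for lower toxicity in this test:
Compound 1 `CSc1c(C)[n+]([O-])c2ccccc2[n+]1[O-]`: > 16 ug/mL (a limit of the assay, not a number)
Compound 2 `COCCNC(=O)c1ccc2c(c1)[n+]([O-])c(C(C)=O)c(C)[n+]2[O-]`: > 16 ug/mL (a limit of the assay, not a number)
Compound 3 `CCNc1n[n+]([O-])c2ccccc2[n+]1[O-]`: 17 ug/mL

For the measured compounds named here, compound 3 gives the only true number in the set, 17 ug/mL. The rest of the record consists of the limit of > 16 ug/mL in this assay, at which 2 of the 3 values shown sit.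

Compound 4 `[O-][n+]1nc(NC2CCCCC2)[n+]([O-])c2ccccc21` has not yet been measured. Its difference from compound 3 is cyclohexyl in place of ethyl on a nitrogen on an aromatic ring, with cyclohexyl in place of ethyl on a nitrogen on an aromatic ring. Going by the values given here, no measured pair differs in only one place, so the set offers no precedent for this change. No step beyond the scatter is therefore expected in this assay, in either direction. The expected change is a 1.2-fold lower number from compound 3 to compound 4 (0.08 log units; within the scatter). For compound 4 the estimated value is 14 ug/mL, with an expected range of 5 ug/mL to 40 ug/mL.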

Compound 4, half-maximal cytotoxic concentration: 8.9 ug/mL
Estimate against measurement, compound 4: 1.6-fold (0.20 log units) above, and the stated range covers the measured number.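

In this assay, for the compounds shown here, cyclohexyl in place of ethyl on a nitrogen on an aromatic ring gives the first step that can be read in this set (a 1.9-fold lower number from compound 3 to compound 4 (0.28 log units; within the scatter)). Going by these compounds alone, this position therefore takes a six-membered non-aromatic ring of carbon only without a step beyond the scatter, which the earlier compounds could not show.

As far as these compounds go, what a longer chain, an amine or a carboxylic acid would do on this nitrogen stays open. Compound 1 and compound 2 differ from these compounds in more than one place and each gives a limit, not a number: the limit of > 16 ug/mL in this assay, at which 2 of the 4 values shown sit.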